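Urea-to-oxazole amide swap in a diarylurea series

A few compounds are considered here, and "the series" means these few. Any claim that something is new, unique, unknown or untested is made for them only; others in the source may bear on it.

- compound 1: `CC(=O)Nc1cc(NC(=O)Nc2ccc(Cl)c(Cl)c2)ccc1C`, 2100 nM in a functional assay on A375P cells (Homo sapiens) for antiproliferative activity; on this read-out lower numbers stand for stronger inhibition and higher numbers for weaker inhibition
- compound 2: `Cc1ccc(NC(=O)Nc2ccc(Cl)c(Cl)c2)cc1NC(=O)c1ccccc1`, 5800 nM in this assay

Compound 2 holds the highest number of the two in this assay; its nearest neighbour is compound 1, with a 2.8-fold higher number from compound 1 to compound 2 (0.44 log units; beyond the scatter).

Compound 3, `Cc1cc(C(=O)Nc2ccc(C)c(NC(=O)c3ccccc3)c2)no1`, is not yet measured. It differs from compound 2 by 5-methyl-1,2-oxazol-3-yl in place of (3,4-dichlorophenyl)amino on a carbonyl carbon. Among the measured compounds shown here, no measured step touches this part of the molecule: the only step in hand, a 2.8-fold higher number from compound 1 to compound 2 (0.44 log units; beyond the scatter), concerns the other carbonyl carbon and was modest. The present change removes the whole (3,4-dichlorophenyl)amino portion, so it is larger than any change already tested and its outcome cannot be read from the measured pair.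

With nothing in the series to anchor it, the expectation for compound 3 in this assay is a weaker number, 15000 nM, with a wide range from 4000 nM to 60000 nM. The step expected from compound 2 to compound 3 is therefore a 2.6-fold higher number from compound 2 to compound 3 (0.41 log units; beyond the scatter), held with low confidence.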

Compound 3, half-maximal inhibitory concentration: > 30000 nM
Compound 3: no number, only a limit (the forecaster's own chance of this, stated with the estimate: 25%); middle value at least 2.0-fold (0.30 log units) away from the limit.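

For compound 3, this assay gives only a limit and not a number: the limit of > 30000 nM in this assay, at which 1 of the 3 values shown sits. Among the compounds shown here, exchanging (3,4-dichlorophenyl)amino for 5-methyl-1,2-oxazol-3-yl gives an at least 5.1-fold higher number from compound 2 to compound 3 (0.71 log units; beyond the scatter), the first reading at this carbonyl carbon. The earlier pair varied only the other carbonyl carbon, with a 2.8-fold higher number from compound 1 to compound 2 (0.44 log units; beyond the scatter), so the present result adds that antiproliferative activity in this series also responds to the group at this position, and that this exchange does not keep activity within the range of the two earlier compounds.

The exchange changes several things at once: the six-membered carbon ring, the chlorine atoms and the nitrogen with its hydrogen all leave together, so the compounds shown do not tell which of these accounts for the loss, and the full size of the step stays unknown behind the limit. Going by these compounds, a plain phenylamino group or a (5-methyl-1,2-oxazol-3-yl)amino group on this carbonyl carbon would be the comparisons that separate these parts, and the outcome for either remains open.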